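Methoxy Addition on a Dienone Scaffold with Inactive Precursors

A few compounds are considered here, and "the series" means these few. Any claim that something is new, unique, unknown or untested is made for them only; others in the source may bear on it.

Of the compounds shown here, three have been measured in a functional assay on DU-145 cells (Homo sapiens) for cytotoxicity, read by MTT assay, with a stated time of 48 h (on this read-out lower numbers stand for stronger inhibition and higher numbers for weaker inhibition), and each gives only a limit rather than a number.

Compound 1 `COc1ccc(/C=C/C(=O)/C=C/c2cc3ccccc3nc2Cl)cc1` gives the limit > 10000 nM.
Compound 2 `COc1ccc(/C=C/C(=O)/C=C/c2cc3ccccc3nc2Cl)c(OC)c1` gives the limit > 10000 nM.
Compound 3 `COc1ccc(/C=C/C(=O)/C=C/c2cc3ccccc3nc2Oc2ccccc2)c(OC)c1` gives the limit > 10000 nM.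

The change from compound 1 to compound 2 is methoxy in place of hydrogen on an aromatic carbon. In this assay the step is a step that the two limits leave unreadable from compound 1 to compound 2 because of the limit of > 10000 nM in this assay, at which 3 of the 3 values shown sit. The step that the two limits leave unreadable from compound 2 to compound 3 is unreadable for the same reason. The difference between the cores of compound 1 and compound 3 is not broken down here.

Compound 4 `COc1cc(OC)c(/C=C/C(=O)/C=C/c2cc3ccccc3nc2Oc2ccccc2)c(OC)c1` has not been measured. It differs from compound 3 by methoxy in place of hydrogen on an aromatic carbon. This is the same kind of change as from compound 1 to compound 2, though here the place is meta to two methoxy groups rather than meta to a methoxy group. In this assay the expected step is a step that the limit leaves unreadable from compound 3 to compound 4, which rests on compound 2 standing at the limit of > 10000 nM in this assay, at which 3 of the 3 values shown sit. Compound 4 is therefore expected to give about 20000 nM, estimated between 8000 nM and 100000 nM, most probably again as a limit only.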

Compound 4, half-maximal inhibitory concentration: > 10000 nM
Compound 4 was reported as a limit; the forecaster's own chance of this, stated with the estimate: 75%; the middle value does not contradict the limit.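

No size can be read for the change from compound 3 to compound 4, because both results are limits rather than numbers: the limit of > 10000 nM in this assay, at which 4 of the 4 values shown sit. Going by these compounds, whether adding methoxy alters cytotoxicity on these cells at all remains open.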